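A Ketone Becomes an Amide: What Solubility to Expect

The source may report more compounds than this note shows. Statements on the series, on what has been measured and on what is new or still open speak of the compounds shown alone.

The three measured compounds:
- Compound 1, `CCC(=O)c1cc(-c2ccc(S(N)(=O)=O)cc2)n(-c2ccc(Cl)cc2)n1`: in a physicochemical assay for solubility, read by HPLC, in phosphate buffer, measured as kinetic solubility, at pH 7.4 (a lower number here means a less soluble compound, a higher number a more soluble compound), compound 1 gives 41900 nM.
- Compound 2, `CCC(=O)c1cc(-c2ccc(S(N)(=O)=O)cc2)n(-c2ccc(C(F)(F)F)cc2)n1`: in this assay compound 2 gives 7500 nM.
- Compound 3, `CCC(=O)c1cc(-c2ccc(S(N)(=O)=O)cc2)n(-c2ccccc2Cl)n1`: in this assay compound 3 gives 4700 nM.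

Compound 1 holds the highest of the three numbers, and both steps away from it are beyond the scatter: a 5.6-fold lower number from compound 1 to compound 2 (0.75 log units; beyond the scatter) and an 8.9-fold lower number from compound 1 to compound 3 (0.95 log units; beyond the scatter). It is therefore the most soluble of the measured set.

The unmeasured compound 4, `NS(=O)(=O)c1ccc(-c2cc(C(=O)NC3CC3)nn2-c2ccc(Cl)cc2)cc1`, differs from compound 1 in one place: cyclopropylamino in place of ethyl on a carbonyl carbon. The propanoyl group of compound 1 thus becomes a cyclopropylcarbamoyl group, bringing one hydrogen-bond donor and a three-membered ring.

Within the data shown here, both measured steps alter the aromatic ring on the nitrogen, not the carbonyl side, so neither bears directly on this change; they show only that single modest changes elsewhere in the shared core moved solubility downward by modest amounts. Among the measured compounds shown here, with no direct precedent, the expected step in this assay is none beyond the scatter, with wide uncertainty. Compound 4 is therefore estimated at 35000 nM, within 10000 nM to 120000 nM. This estimate means a 1.2-fold lower number from compound 1 to compound 4 (0.08 log units; within the scatter), expected to stay within the usual scatter.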

Compound 4, solubility: 72600 nM
The estimate for compound 4 lay 2.1-fold (0.32 log units) below the measured number, and the stated range covers the measured number.
By their numbers in this assay, from the lowest: compounds 3 and 2 (each within the scatter of the next); then compounds 1 and 4 (each within the scatter of the next).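

In this assay, cyclopropylamino in place of ethyl on a carbonyl carbon gives a 1.7-fold higher number from compound 1 to compound 4 (0.24 log units; within the scatter) and so cannot be told apart from repeat-measurement noise. Among the compounds shown, this is the only view of the carbonyl side of the shared core, and the exchange of propanoyl for cyclopropylcarbamoyl, which brings a hydrogen-bond donor and a three-membered ring, stays within the scatter, whereas the two changes on the aromatic ring on the nitrogen, a 5.6-fold lower number from compound 1 to compound 2 (0.75 log units; beyond the scatter) and an 8.9-fold lower number from compound 1 to compound 3 (0.95 log units; beyond the scatter), went beyond it. No evidence is at hand that bears on what lies behind this result.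

As far as these compounds go, this is a single example, so it remains open whether other groups on the same carbonyl carbon, such as dimethylamino, morpholine or a longer chain like butylamino, would also stay within the scatter. From the compounds shown here alone, it is equally open whether cyclopropylamino would give so small a step on the cores of compound 2 and compound 3, whose aromatic rings on the nitrogen differ from that of compound 1.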